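The source may report more compounds than this note shows. Statements on the series, on what has been measured and on what is new or still open speak of the compounds shown alone.

Series notes. Among the measured compounds shown here, compound 1 `O=C(CN1CN(c2ccccc2)C2(CCN(C(=O)c3ccc(C4CCCCC4)cc3)CC2)C1=O)NCCCCO` holds the second highest of the three numbers measured so far in an assay on HEK293 cells for displacement of a labelled ligand from NPC1-like intracellular cholesterol transporter 1 (Homo sapiens) (on this read-out lower numbers stand for stronger inhibition and higher numbers for weaker inhibition), giving 10300 nM. Compound 2 `CC(C)(C)OC(=O)NCCCCCNC(=O)CN1CN(c2ccccc2)C2(CCN(C(=O)c3ccc(C(C)(C)C)cc3)CC2)C1=O` gives 13700 nM, within the scatter of compound 1. Compound 3 `CCC1CCCN(C(=O)CN2CN(c3ccccc3)C3(CCN(C(=O)c4ccc(C(C)(C)C)cc4)CC3)C2=O)C1` gives 3900 nM, a lower number beyond the scatter relative to compound 1. Compound 4 `CS(=O)(=O)NCCNC(=O)CN1CN(c2ccccc2)C2(CCN(C(=O)c3ccc(C4CCCCC4)cc3)CC2)C1=O` is not yet measured in this assay; it differs from compound 1 by methanesulfonamido in place of 2-hydroxyethyl on a saturated chain carbon, two bonds along the chain from an amide-type nitrogen. No measured pair in the set isolates this change, so nothing shown speaks to its size or direction. The step from compound 1 to compound 4 is therefore expected to be a 1.1-fold lower number from compound 1 to compound 4 (0.04 log units; within the scatter), none beyond the scatter either way. Compound 4 is estimated at 9500 nM, with a range from 3500 nM to 26000 nM.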

Compound 4, half-maximal inhibitory concentration: 2100 nM
For compound 4 the middle estimate is 4.5-fold (0.66 log units) above the measured one; measured number below the stated range.
By their numbers in this assay, from the lowest: compounds 4 and 3 (each within the scatter of the next); then compounds 1 and 2 (each within the scatter of the next).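

In this assay, among the compounds shown here, the change of methanesulfonamido in place of 2-hydroxyethyl, on a saturated chain carbon two bonds along the chain from an amide-type nitrogen, gives a 4.9-fold lower number from compound 1 to compound 4 (0.69 log units; beyond the scatter) and supplies the first one-place comparison. It shows that the number responds to the group carried on this chain, with the donor count unchanged and one more acceptor entering. Nothing shown explains the step.

From the compounds shown here alone, it remains open whether a carboxylic acid, an amine or a shorter sulfonamide-bearing chain at this position would give a similar step.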